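The source may report more compounds than this note shows. Statements on the series, on what has been measured and on what is new or still open speak of the compounds shown alone.

Among the measured compounds shown here, in an assay on cells for inhibition of Amine oxidase [flavin-containing] B (Homo sapiens), read by fluorescence and Amplex Red, with a stated time of 15 min (on this read-out higher numbers stand for weaker inhibition and lower numbers for stronger inhibition), compound 2, `Cc1cccc2cc(-c3ccccc3Br)oc12`, gives 9680 nM, the higher of the two numbers measured so far. Compound 1, `Cc1ccc2oc(-c3ccccc3Br)cc2c1`, gives 200 nM in this assay, and the gap between the two lies well beyond the scatter of repeated measurements. Compound 3, `Brc1ccccc1-c1cc2ccccc2o1`, has not yet been measured. It differs from compound 2 by hydrogen in place of methyl on an aromatic carbon. For the measured compounds named here, no measured pair shows this exact change, so the size of the step is not known from a direct comparison. Given that compound 1, which carries its methyl elsewhere on the shared core, reaches 200 nM, a move toward stronger inhibition, beyond the scatter, is expected for compound 3. Compound 3 is therefore estimated at 1500 nM, with a range from 400 nM to 6000 nM. This estimate means an expected step of a 6.5-fold lower number from compound 2 to compound 3 (0.81 log units; beyond the scatter).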

Compound 3, half-maximal inhibitory concentration: 1130 nM
Compound 3: middle estimate off by 1.3-fold (0.12 log units), on the high side, within the range that was stated.
By their numbers in this assay, from the lowest: compound 1; then compound 3; then compound 2.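

Compound 3, with hydrogen in place of methyl, gives a reference for both methylated compounds. In this assay the change gives an 8.6-fold lower number from compound 2 to compound 3 (0.93 log units; beyond the scatter) and thus ties the methyl of compound 2 to weaker inhibition, while it gives a 5.7-fold higher number from compound 1 to compound 3 (0.75 log units; beyond the scatter) and thus ties the methyl of compound 1 to stronger inhibition. The same group therefore moves the number in opposite directions depending on where it sits on the shared core, and no measurement at hand bears on why.

On these data alone, whether an amine or a methoxy group at either place would follow the same opposite trend remains open. So does the outcome of placing methyl elsewhere on the shared core.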